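The source may report more compounds than this note shows. Statements on the series, on what has been measured and on what is new or still open speak of the compounds shown alone.

Values in a functional assay on ECa-109 cells (Homo sapiens) for cytotoxicity, read by MTT assay, with a stated time of 72 h; on this read-out higher numbers stand for weaker inhibition and lower numbers for stronger inhibition:
- Compound 1 `CN(C)c1ccc(C=C2C(=O)N(c3ccc(Cl)cc3)N(c3ccc(Cl)cc3)C2=O)cc1`: > 128000 nM (a limit)
- Compound 2 `O=C1C(=Cc2ccc(F)cc2)C(=O)N(c2ccc(Cl)cc2)N1c1ccc(Cl)cc1`: 35600 nM
- Compound 3 `O=C1C(=Cc2cccc(Cl)c2)C(=O)N(c2ccc(Cl)cc2)N1c1ccc(Cl)cc1`: 22600 nM

The value for compound 1 is a limit and not a number. Compound 3 cannot be separated from compound 2, given a 1.6-fold lower number from compound 2 to compound 3 (0.20 log units; within the scatter). Both lie clear of the limit set by compound 1.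

Compound 4 `COc1cccc(C=C2C(=O)N(c3ccc(Cl)cc3)N(c3ccc(Cl)cc3)C2=O)c1OC` is still unmeasured. It has 2,3-dimethoxyphenyl in place of 3-chlorophenyl on a double-bonded chain carbon bound to a double-bonded ring carbon.

Two measured steps start from the limit: an at least 3.5-fold lower number from compound 1 to compound 2 (0.55 log units; beyond the scatter), and an at least 5.6-fold lower number from compound 1 to compound 3 (0.75 log units; beyond the scatter). Among the compounds with values here, both of these involve loss of the dimethylamino group, while the one exchange among halogen-bearing compounds stays small. Compound 4 resembles compound 1 in having no halogen on this aryl group, so a modest move toward weaker inhibition is expected in this assay, smaller than an at least 5.6-fold lower number from compound 1 to compound 3 (0.75 log units; beyond the scatter). The expected change is a 1.9-fold higher number from compound 3 to compound 4 (0.27 log units; within the scatter). For compound 4 the estimated value is 42000 nM, with an expected range of 15000 nM to 115000 nM.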

Compound 4, half-maximal inhibitory concentration: 6800 nM
Compound 4: middle estimate off by 6.2-fold (0.79 log units), on the high side; measured number outside the range, below it.
By their numbers in this assay, from the lowest: compound 4; then compounds 3 and 2 (each within the scatter of the next). At a limit, above all of these: compound 1.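

Within the data shown here, at this place, on a double-bonded chain carbon bound to a double-bonded ring carbon, 2,3-dimethoxyphenyl gives the lowest number so far in this assay: a 3.3-fold lower number from compound 3 to compound 4 (0.52 log units; beyond the scatter), and a 5.2-fold lower number from compound 2 to compound 4 (0.72 log units; beyond the scatter). A halogen on this aryl group is therefore not required for the lower numbers, and the absence of one does not by itself go with weak inhibition, as compound 1 and compound 4 both lack a halogen there yet lie far apart. Compound 1 stands at a limit, and an at least 18-fold lower number from compound 1 to compound 4 (1.27 log units; beyond the scatter) gives a bound only: the limit of > 128000 nM in this assay, at which 1 of the 4 values shown sits.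

The compounds shown do not tell whether a single methoxy group on this aryl group would do as well as the two in compound 4. Going by these compounds, how a hydroxy group or a carboxylic acid on this aryl group would read also stays open.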